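A few compounds are considered here, and "the series" means these few. Any claim that something is new, unique, unknown or untested is made for them only; others in the source may bear on it.

Measured compounds:
- compound 1, `C/C=C/C(=O)N(Cc1cccc(O)c1)c1cc(OC)c(OC)c(OC)c1`: 6700 nM
- compound 2, `COc1ccc(CN(C(=O)CCCl)c2cc(OC)c(OC)c(OC)c2)cc1O`: 150 nM
- compound 3, `COc1ccc(CN(C(C)=O)c2cc(OC)c(OC)c(OC)c2)cc1O`: 270 nM

In a functional assay on HCT-116 cells (Homo sapiens) for inhibition, read by MTT assay, with a stated time of 48 h (on this read-out higher numbers stand for weaker inhibition and lower numbers for stronger inhibition), compound 3 gives 270 nM, the second highest of the three numbers. Its nearest neighbour is compound 2, which gives 150 nM; the pair differ by a 1.8-fold higher number from compound 2 to compound 3 (0.26 log units; within the scatter), a change that stays within the scatter. Compound 1, with its different amide chain and its differently placed hydroxyl, gives 6700 nM and lies far from compound 3, beyond the scatter.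

Compound 4, `COCC(=O)N(Cc1ccc(OC)c(O)c1)c1cc(OC)c(OC)c(OC)c1`, follows from compound 3 by the change (methoxy in place of hydrogen on a saturated chain carbon bound to a carbonyl carbon).

Among the compounds with values here, only one measured step touches the same place: a 1.8-fold higher number from compound 2 to compound 3 (0.26 log units; within the scatter), where a chloromethyl and a hydrogen on that chain carbon gave numbers within the scatter of one another. On that single precedent, a methoxy at the same place is expected to leave this assay largely unchanged, with no step beyond the scatter in either direction foreseen. Compound 4 is therefore estimated at 250 nM, within 100 nM to 700 nM, which means an expected step of a 1.1-fold lower number from compound 3 to compound 4 (0.03 log units; within the scatter).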

Compound 4, half-maximal inhibitory concentration: 230 nM
Compound 4: the middle estimate sits 1.1-fold (0.04 log units) above what was measured; low and high end bracket the measured number.
By their numbers in this assay, from the lowest: compounds 2, 4 and 3 (each within the scatter of the next); then compound 1.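

In this assay, methoxy in place of hydrogen on the saturated chain carbon bound to a carbonyl carbon gives a 1.2-fold lower number from compound 3 to compound 4 (0.07 log units; within the scatter) and methoxy in place of chloromethyl gives a 1.5-fold higher number from compound 2 to compound 4 (0.19 log units; within the scatter), so neither exchange moves the number beyond the scatter. The earlier compounds shown here compared only hydrogen and chloromethyl at this place; with methoxy as a third group, all three of compound 2, compound 3 and compound 4 now lie within the scatter of one another. Nothing available explains why these groups read alike.

As far as these compounds go, whether an amine, a carboxylic acid or a longer chain at this place would stay within the same range remains open. Compound 1, at 6700 nM, differs from these compounds in more than one place, so its number cannot be tied to any single change.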